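A few compounds are considered here, and "the series" means these few. Any claim that something is new, unique, unknown or untested is made for them only; others in the source may bear on it.

Within the data shown here, in a functional assay on cells (Erythrocyte, Homo sapiens) for inhibition, read by spectrophotometry and hemolysis, with a stated time of 10 min (a higher number here means a weaker inhibitor, a lower number a stronger inhibitor), two members have numbers so far. Compound 1 `O=C(CCCc1nc2ccccc2c(=O)[nH]1)N/N=C/c1ccc([N+](=O)[O-])cc1` gives 52000000 nM, the lower of the two, and compound 2 `COc1cc(/C=N/NC(=O)CCc2nc3ccccc3c(=O)[nH]2)cc(O)c1O` gives 261000000 nM, a gap beyond the scatter. Compound 1 is thus the stronger inhibitor of this pair. The next entry, compound 3 `O=C(CCCc1nc2ccccc2c(=O)[nH]1)N/N=C/c1ccc(O)c(O)c1`, keeps the core of compound 1 and has 3,4-dihydroxyphenyl in place of 4-nitrophenyl on a carbon with a double bond to nitrogen. Among the measured compounds shown here, no measured pair isolates this change, so the evidence is thin. Compound 2 also lacks the 4-nitrophenyl and reads 261000000 nM, which points to a moderate move towards a higher number, probably beyond the scatter. The expected step is a 2.1-fold higher number from compound 1 to compound 3 (0.33 log units; beyond the scatter). For compound 3 the estimated value is 110000000 nM, with an expected range from 30000000 nM to 400000000 nM.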

Compound 3, half-maximal inhibitory concentration: 300000000 nM
For compound 3 the middle estimate is 2.7-fold (0.44 log units) below the measured one; the measured number falls inside the stated range.
By their numbers in this assay, from the lowest: compound 1; then compounds 2 and 3 (each within the scatter of the next).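

Among these compounds, compound 3 gives the first direct reading at this position: on a carbon with a double bond to nitrogen, 3,4-dihydroxyphenyl in place of 4-nitrophenyl gives a 5.8-fold higher number from compound 1 to compound 3 (0.76 log units; beyond the scatter) in this assay with the rest of compound 1 unchanged. The earlier comparison could only hint at this, as compound 2 differs from compound 1 in more than one place. This single pair cannot separate losing the nitro group from gaining the two hydroxyl groups, and no measurement at hand accounts for the step.

Open, as far as these compounds go, is whether an unsubstituted phenyl, a 4-hydroxyphenyl or a 4-aminophenyl on the same carbon would read closer to compound 1 or to compound 3. Also open, from the compounds shown here alone, is whether the step between these two groups holds on a longer chain.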